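The compounds below may be only part of what the source reports. "The series", "measured", "known", "first", "only" and "open" are said of these compounds alone.

Compound 3 `COC(=O)/C(=C\c1ccc(OC(=O)c2cc(OC)cc(OC)c2OC)cc1)Sc1ccnc2cc(Cl)ccc12` stands second highest of the three numbers in a functional assay on Jurkat E6.1 cells (Homo sapiens) for cytotoxicity, read by MTT assay, with a stated time of 24 h (on this read-out higher numbers stand for weaker inhibition and lower numbers for stronger inhibition), where compound 3 gives 15600 nM. Compound 1 `COC(=O)/C(=C\c1ccc(OC(=O)c2ccc(OC)cc2)cc1)Sc1ccnc2cc(Cl)ccc12` gives 11000 nM, and compound 2 `COC(=O)/C(=C\c1ccc(OC(=O)c2ccccc2OC)cc1)Sc1ccnc2cc(Cl)ccc12` gives 44700 nM. Compound 4 `COC(=O)/C(=C\c1ccc(OC(=O)c2ccc(OC)c(OC)c2OC)cc1)Sc1ccnc2cc(Cl)ccc12` differs from compound 3 in one respect: 2,3,4-trimethoxyphenyl in place of 2,3,5-trimethoxyphenyl on a carbonyl carbon. The measured steps that swap one methoxy-bearing phenyl for another on that carbonyl carbon are a 1.4-fold higher number from compound 1 to compound 3 (0.15 log units; within the scatter), a 2.9-fold lower number from compound 2 to compound 3 (0.46 log units; beyond the scatter) and a 4.1-fold higher number from compound 1 to compound 2 (0.61 log units; beyond the scatter). Such swaps have shifted the number from within the scatter to modestly beyond it, in both directions, so the step is expected to be small, a 1.2-fold higher number from compound 3 to compound 4 (0.06 log units; within the scatter), with no confident direction. Compound 4 is therefore estimated at 18000 nM in this assay, within a range from 7000 nM to 45000 nM.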

Compound 4, half-maximal inhibitory concentration: 2410 nM
Beside the measured number, compound 4's estimate is 7.5-fold (0.87 log units) above it; measured number below the stated range.
By their numbers in this assay, from the lowest: compound 4; then compounds 1 and 3 (each within the scatter of the next); then compound 2.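

Replacing 2,3,5-trimethoxyphenyl with 2,3,4-trimethoxyphenyl on the carbonyl carbon rearranges the same atoms, yet gives a 6.5-fold lower number from compound 3 to compound 4 (0.81 log units; beyond the scatter) in this assay, so the arrangement of the methoxy groups matters here, not only their number. The 2,3,4-trimethoxyphenyl group also gives a clearly lower number than either single-methoxy group, with a 4.6-fold lower number from compound 1 to compound 4 (0.66 log units; beyond the scatter) and a 19-fold lower number from compound 2 to compound 4 (1.27 log units; beyond the scatter), whereas compound 3 could not be separated from compound 1. No supporting evidence explains this shift. On these data alone, whether all three methoxy groups are needed remains open, as does the effect of a plain phenyl or an aminophenyl on this carbonyl carbon.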